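Thiophene sulfonamide ureas and thioureas: cytotoxicity notes

The source may report more compounds than this note shows. Statements on the series, on what has been measured and on what is new or still open speak of the compounds shown alone.

The series is built on two cores. Compound 3 `Cc1ccc(-c2ccsc2S(=O)(=O)NCCNC(=O)Nc2cc(Cl)cc(Cl)c2)c(Oc2ccc(O)c(O)c2)c1` and compound 1 `Cc1ccc(-c2ccsc2S(=O)(=O)NCCNC(=S)Nc2ccc([N+](=O)[O-])cc2)c(Oc2ccc(O)c(O)c2)c1` share one core; compound 2 `O=C(NCCNS(=O)(=O)c1ccc(-c2ccccc2O[C@H]2CC[C@H](O)CC2)s1)Nc1cc(Cl)cc(Cl)c1` and the unmeasured compound 4 `O=[N+]([O-])c1ccc(NC(=S)NCCNS(=O)(=O)c2ccc(-c3ccccc3O[C@H]3CC[C@H](O)CC3)s2)cc1` share the other. The difference between the two cores is not broken down here.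

In an ADME assay on HEK-293T cells (Homo sapiens) for cytotoxicity, read by CCK-8 assay, with a stated time of 48 h (a lower number here means a stronger inhibitor, a higher number a weaker inhibitor), compound 3 gives 6700 nM. In this assay compound 1 gives 8200 nM. The change from compound 3 to compound 1 is a group of 12 heavy atoms (7 carbon, 2 nitrogen, 2 oxygen, 1 sulfur; one six-membered aromatic ring of carbon only) in place of a group of 11 heavy atoms (7 carbon, 1 nitrogen, 1 oxygen, 2 chlorine; one six-membered aromatic ring of carbon only), on an amine nitrogen, and it produces a 1.2-fold higher number from compound 3 to compound 1 (0.09 log units; within the scatter). On the other core, compound 2 is reported in this assay only as a limit, > 50000 nM. This sits at the limit of > 50000 nM in this assay, at which 1 of the 3 values shown sits.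

Compound 4 carries the same change made on compound 2: a group of 12 heavy atoms (7 carbon, 2 nitrogen, 2 oxygen, 1 sulfur; one six-membered aromatic ring of carbon only) in place of a group of 11 heavy atoms (7 carbon, 1 nitrogen, 1 oxygen, 2 chlorine; one six-membered aromatic ring of carbon only), on an amine nitrogen. The place is the same as on the first core, so this is the same change.

The step expected for compound 4 is a step that the limit leaves unreadable from compound 2 to compound 4, because a 1.2-fold higher number from compound 3 to compound 1 (0.09 log units; within the scatter) is within the scatter on the first core. Since compound 2 is itself only a limit, compound 4 in this assay is expected to land at or beyond that limit as well, and the estimate for compound 4 is 70000 nM, with a range from 30000 nM to 200000 nM.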

Compound 4, half-maximal inhibitory concentration: 10500 nM
Estimate against measurement, compound 4: 6.7-fold (0.82 log units) above, and the stated range ends above it.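

In this assay, the change of (3,5-dichlorophenyl)carbamoyl to the larger group on the amine nitrogen gives an at least 4.7-fold lower number from compound 2 to compound 4 (0.67 log units; beyond the scatter). From the compounds shown here alone, the change does not carry over as the same step from one core to the other: the same change on two cores in this assay, a 1.2-fold higher number (0.09 log units; within the scatter) from compound 3 to compound 1 and an at least 4.7-fold lower number (0.67 log units; beyond the scatter) from compound 2 to compound 4, at least 5.8-fold (0.76 log units) apart, beyond the scatter of two such steps The step on the second core rests on a limit of the assay for compound 2, so its full size stays unknown, and this single comparison shows neither which feature of the two cores separates the steps nor how any other change would carry across them.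

Among the compounds shown, the urea link always comes with the 3,5-dichlorophenyl ring and the thiourea link with the nitrophenyl ring, so the share of each part in the step stays open. Also open, going by these compounds, is how a different group on the same amine nitrogen, such as a simple acetyl or a longer alkyl chain, would read on either core, and whether the two cores would then part in the same way.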